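The source may report more compounds than this note shows. Statements on the series, on what has been measured and on what is new or still open speak of the compounds shown alone.

Three compounds share one core and differ only in the group on the aromatic nitrogen of the five-membered ring. Compound 1 `Nc1ccccc1NC(=O)c1ccc(CNc2nc(Cl)nc3c2ncn3Cc2ccccc2)cc1` carries a benzyl group and in a functional assay on HepG2 cells (Homo sapiens) for antiproliferative activity, read by CCK-8 assay, with a stated time of 72 h, tested at 8 uM (on this read-out higher numbers stand for a stronger effect at the one concentration tested and lower numbers for a weaker effect), compound 1 gives 5.32%. Compound 2 `COC(CCn1cnc2c(NCc3ccc(C(=O)Nc4ccccc4N)cc3)nc(Cl)nc21)OC` gives 34.2%, and compound 3 `CCCn1cnc2c(NCc3ccc(C(=O)Nc4ccccc4N)cc3)nc(Cl)nc21` gives 14.1%. Compound 3 therefore stands second highest of the three numbers, with compound 1 nearest, a number 8.8 percentage points higher from compound 1 to compound 3 (within the scatter), and compound 2 furthest, a number 20.1 percentage points lower from compound 2 to compound 3 (beyond the scatter). The largest step among the measured compounds is a number 28.9 percentage points higher from compound 1 to compound 2 (beyond the scatter).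

Compound 4 `Nc1ccccc1NC(=O)c1ccc(CNc2nc(Cl)nc3c2ncn3C2CCCC2)cc1` is not yet measured. It differs from compound 3 by cyclopentyl in place of propyl on an aromatic nitrogen. Going by the values given here, none of the measured steps exchanges one saturated carbon-only group for another of the same kind: the measured steps replace phenyl or introduce or remove dimethoxymethyl, and the two of them that moved beyond the scatter both involve the dimethoxy-bearing chain of compound 2. Among the compounds with values here, the change from propyl to cyclopentyl introduces no donor or acceptor, and the one comparison between two groups lacking such atoms, a number 8.8 percentage points higher from compound 1 to compound 3 (within the scatter), stayed within the scatter. Compound 4 is therefore expected to show a step of a number 1.9 percentage points higher from compound 3 to compound 4 (within the scatter), which is no change beyond the scatter. The estimate for compound 4 is 16%, with a range from 4% to 30%.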

Compound 4, a percentage reported as inhibition, at one concentration (the size of the read-out at that concentration, not a potency): 74.9%
Estimate against measurement, compound 4: 58.9 percentage points below; measured number above the stated range.
By their numbers in this assay, from the lowest: compounds 1 and 3 (each within the scatter of the next); then compound 2; then compound 4.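

In this assay, going by these compounds alone, the group on the aromatic nitrogen can move the read-out much further than the earlier compounds showed, even when the exchange brings in no hydrogen-bond donor or acceptor: cyclopentyl in place of propyl gives a number 60.8 percentage points higher from compound 3 to compound 4 (beyond the scatter) and swaps one carbon-only group for another. The cyclopentyl group also outdoes the two other groups at this position, with benzyl giving way to it in a number 69.6 percentage points higher from compound 1 to compound 4 (beyond the scatter) and 3,3-dimethoxypropyl in a number 40.7 percentage points higher from compound 2 to compound 4 (beyond the scatter), so the highest number here now belongs to a carbon-only ring and no longer to the dimethoxy-bearing chain. A ring as such does not go with a high number in this set: compound 1 also carries one, in its benzyl group, and stays within the scatter of compound 3.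

From the compounds shown here alone, whether the gain depends on this particular ring size, on the ring itself or on branching stays open, and a cyclobutyl group, a cyclohexyl group or an isopropyl group on the same nitrogen would tell these readings apart. The data shown offer no measurement that explains the size of this step.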